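A few compounds are considered here, and "the series" means these few. Any claim that something is new, unique, unknown or untested is made for them only; others in the source may bear on it.

Measured compounds:
compound 1 `CC(C)c1onc(-c2c(Cl)cccc2Cl)c1COc1ccc(N(C)Cc2ccc(OCCO)cc2)c(C(F)(F)F)n1` — 155 nM
compound 2 `CC(Nc1ccc(C(=O)O)cc1)c1ccc(OCc2c(-c3c(Cl)cccc3Cl)noc2C2CC2)nc1C(F)(F)F` — 202 nM
compound 3 `CC(c1ccc(OCc2c(-c3c(Cl)cccc3Cl)noc2C2CC2)nc1C(F)(F)F)N(C)c1ccc(C(=O)O)cc1` — 182 nM

All three were tested in a functional assay on HEK293 cells for agonist activity at Bile acid receptor (Homo sapiens), read by a luciferase reporter; on this read-out higher numbers stand for an effect only at larger amounts of compound and lower numbers for an effect already at smaller amounts. Compound 2 gives the highest of the three numbers in this assay, yet its gaps to compound 3 and to compound 1 both lie within the usual scatter, so the three compounds cannot be told apart on this evidence.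

Compound 4 `O=C(O)c1ccc(OCc2ccc(OCc3c(-c4c(Cl)cccc4Cl)noc3C3CC3)nc2C(F)(F)F)cc1` has not yet been measured. It arises from compound 2 by a single change: (4-carboxyphenoxy)methyl in place of 1-((4-carboxyphenyl)amino)ethyl on an aromatic carbon. For the measured compounds named here, only one measured step touches this spot: a 1.1-fold lower number from compound 2 to compound 3 (0.05 log units; within the scatter), which shows that putting a methyl on that nitrogen left the number essentially unchanged. Going by the values given here, the change to compound 4 goes further, exchanging the amino-bearing ethyl link for an oxygen-bearing methyl link, and no measured pair covers that exchange directly. For compound 4 the expected step is therefore small, a 1.2-fold higher number from compound 2 to compound 4 (0.09 log units; within the scatter), but with wide uncertainty. Compound 4 is estimated at 250 nM, within a range of 80 nM to 800 nM.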

Compound 4, half-maximal effective concentration: 38 nM
Estimate against measurement, compound 4: 6.6-fold (0.82 log units) above; measured number below the stated range.
By their numbers in this assay, from the lowest: compound 4; then compounds 1, 3 and 2 (each within the scatter of the next).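

Replacing 1-((4-carboxyphenyl)amino)ethyl with (4-carboxyphenoxy)methyl on this aromatic carbon, ortho to a trifluoromethyl group, gives in this assay a 5.3-fold lower number from compound 2 to compound 4 (0.73 log units; beyond the scatter). For the compounds shown here, this is the first step to go beyond the scatter, so this position can respond to a change in the link to the 4-carboxyphenyl ring, whereas adding a methyl on the nitrogen gave only a 1.1-fold lower number from compound 2 to compound 3 (0.05 log units; within the scatter). Nothing shown explains why the number falls at this position.

The change swaps nitrogen for oxygen and removes the branching methyl in one step, so the compounds shown cannot say which of these matters. A (4-carboxyphenyl)aminomethyl group or a 1-(4-carboxyphenoxy)ethyl group at this position would separate the two.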